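Arylthio Replacement in a Diaminoquinoxaline Growth-Inhibition Series

The compounds below may be only part of what the source reports. "The series", "measured", "known", "first", "only" and "open" are said of these compounds alone.

Three members of the series carry numbers in a functional assay on SK-MEL-28 cells (Homo sapiens) for inhibition, read by sulforhodamine B assay, with a stated time of 48 h; on this read-out higher numbers stand for weaker inhibition of growth and lower numbers for stronger inhibition of growth. Compound 1 `Nc1cc(N)c2nc(-c3ccccc3)c(Oc3ccc(Cl)c(Cl)c3)nc2c1` gives 21400 nM in this assay. Compound 2 `Nc1cc(N)c2nc(-c3ccccc3)c(NCc3ccc(F)cc3)nc2c1` gives 1910 nM, and compound 3 `COc1ccc(CNc2nc3cc(N)cc(N)c3nc2-c2ccccc2)cc1` gives 17400 nM. Compound 2 therefore holds the lowest number of the three, with the other two separated from it by steps that are both beyond the scatter: an 11-fold lower number from compound 1 to compound 2 (1.05 log units; beyond the scatter) and a 9.1-fold higher number from compound 2 to compound 3 (0.96 log units; beyond the scatter).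

The next candidate is compound 4 `Nc1cc(N)c2nc(-c3ccccc3)c(Sc3ccc(Cl)c(Cl)c3)nc2c1`. Relative to compound 2 it differs in one place: (3,4-dichlorophenyl)sulfanyl in place of (4-fluorobenzyl)amino on an aromatic carbon. The change returns the 3,4-dichlorophenyl substituent seen in compound 1, now attached through sulfur rather than oxygen, and removes the benzylamino linkage that distinguished compound 2.

The step that bears most directly on this change is an 11-fold lower number from compound 1 to compound 2 (1.05 log units; beyond the scatter), which moved the series away from a dichlorophenyl-linked substituent and produced a large gain. Reversing that direction suggests a step back toward compound 1. Among the measured compounds shown here, no measured pair contrasts a sulfur link with an oxygen link, so the size of that part of the change is unknown. On the basis of compound 1 at 21400 nM, compound 4 is expected to show a step of a 7.9-fold higher number from compound 2 to compound 4 (0.90 log units; beyond the scatter) in this assay, an increase well beyond the scatter. The estimate for compound 4 is 15000 nM, with a range of 5000 nM to 45000 nM.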

Compound 4, concentration for 50% growth inhibition: 13800 nM
Compound 4: the middle estimate sits 1.1-fold (0.04 log units) above what was measured; the range from low to high includes it.
By their numbers in this assay, from the lowest: compound 2; then compounds 4, 3 and 1 (each within the scatter of the next).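

In this assay, replacing (4-fluorobenzyl)amino with (3,4-dichlorophenyl)sulfanyl on this aromatic carbon gives a 7.2-fold higher number from compound 2 to compound 4 (0.86 log units; beyond the scatter) and shows that a second dichlorophenyl-bearing substituent also falls well short of compound 2 at this position. The first direct contrast of a sulfur link with an oxygen link, a 1.6-fold lower number from compound 1 to compound 4 (0.19 log units; within the scatter) in the same assay, does not separate (3,4-dichlorophenyl)sulfanyl from 3,4-dichlorophenoxy, so the identity of this link atom has no readable effect on the 3,4-dichlorophenyl pair. Nothing at hand accounts for either step.

Compound 2 and compound 4 differ at once in the link atom, the benzyl carbon and the substituents on the aromatic ring, so the compounds shown do not assign the difference between them to any one of these features. A (3,4-dichlorobenzyl)amino group or a (4-fluorophenyl)sulfanyl group at this position would begin to separate those features, while a (4-fluorophenyl)amino group would test the (4-fluorobenzyl)amino substituent without its benzyl carbon.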